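The source may report more compounds than this note shows. Statements on the series, on what has been measured and on what is new or still open speak of the compounds shown alone.

The compounds here share one core and differ in the group on a nitrogen on an aromatic ring. In a functional assay on MDA-MB-435 cells (Homo sapiens) for cytotoxicity, read by MTT assay, with a stated time of 72 h (a higher number here means a weaker inhibitor, a lower number a stronger inhibitor), compound 1 (`Nc1cccc(Nc2c(C(=O)NCc3ccc(F)cc3)nc(Br)c3cccnc23)c1`) gives 8000 nM as its half-maximal inhibitory concentration, compound 2 (`NCCCNc1c(C(=O)NCc2ccc(F)cc2)nc(Br)c2cccnc12`) gives 5000 nM and compound 3 (`Nc1ccc(Nc2c(C(=O)NCc3ccc(F)cc3)nc(Br)c3cccnc23)cc1`) gives 7000 nM. Compound 3 thus lies within the scatter of both others, and none of the three stands apart.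

Compound 4 (`O=C(NCc1ccc(F)cc1)c1nc(Br)c2cccnc2c1NCc1ccc(F)cc1`) has 4-fluorobenzyl in place of 4-aminophenyl on that nitrogen (4-fluorobenzyl in place of 4-aminophenyl on a nitrogen on an aromatic ring). Three measured steps change the same place. Putting 3-aminopropyl in place of 3-aminophenyl gives a 1.6-fold lower number from compound 1 to compound 2 (0.20 log units; within the scatter), and putting 4-aminophenyl in place of 3-aminophenyl gives a 1.1-fold lower number from compound 1 to compound 3 (0.06 log units; within the scatter). None of these compounds carries 4-fluorobenzyl on this nitrogen, and each group measured there has an amino group, so the new group is not directly covered by the data. Judged by a 1.4-fold higher number from compound 2 to compound 3 (0.15 log units; within the scatter), a change of group here is expected to move the number little in this assay. The estimate is a 1.2-fold lower number from compound 3 to compound 4 (0.07 log units; within the scatter), which is no expected step beyond the scatter. The range is kept wide for a group not yet tested in this place. Compound 4 is expected at 6000 nM, with an estimated range from 2000 nM to 15000 nM.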

Compound 4, half-maximal inhibitory concentration: > 20000 nM
Compound 4 was reported as a limit; the forecaster's own chance of this, stated with the estimate: 15%; middle value at least 3.3-fold (0.52 log units) away from the limit.
By their numbers in this assay, from the lowest: compounds 2, 3 and 1 (each within the scatter of the next). At a limit, above all of these: compound 4.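

In this assay compound 4 is reported only as a limit, not as a number, and what follows rests on that one reading: the limit of > 20000 nM in this assay, at which 1 of the 4 values shown sits.

The three earlier groups on this nitrogen, 3-aminophenyl, 3-aminopropyl and 4-aminophenyl, gave values within the scatter of each other, so the position seemed to tolerate a change of group, but 4-fluorobenzyl ends that picture, with an at least 2.8-fold higher number from compound 3 to compound 4 (0.45 log units; beyond the scatter), an at least 4.0-fold higher number from compound 2 to compound 4 (0.60 log units; beyond the scatter) and an at least 2.5-fold higher number from compound 1 to compound 4 (0.39 log units; beyond the scatter). The group on this nitrogen therefore can matter in this cell assay, and among these four compounds the three groups with an amino group stay clear of the limit, while the one without it reaches the limit, with no compound going against this.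

The change from compound 3 to compound 4 removes the amino group, adds a fluorine and turns an aryl group into a benzyl group all at once, so the compounds shown cannot say which of these counts. On these data alone, a plain benzyl group or a 4-aminobenzyl group on this nitrogen would begin to separate them, and the true size of the steps stays open while compound 4 is known only as a limit.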